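This account rests on a few compounds, and the source may have more. Where it says the series, first, only, none or still open, it means among the compounds named here.

Measured so far:
Compound 1 `CC(C)c1cccc(C(C)C)c1OC(=O)NS(=O)(=O)N1CCOCC1`: > 100000 nM
Compound 2 `CC(C)c1cccc(C(C)C)c1OC(=O)NS(=O)(=O)Oc1ccc(F)cc1F`: > 50000 nM

Of the compounds shown here, two have been measured in an assay on liver for inhibition of sterol O-acyltransferase 1 (Rattus norvegicus), using microsomes; a higher number here means a weaker inhibitor, a lower number a stronger inhibitor. In this assay compound 1 gives > 100000 nM, which is a limit of the assay and not a number. In this assay compound 2 gives > 50000 nM, likewise a limit rather than a number. Going by the values given here, the one step between them, a step that the two limits leave unreadable from compound 1 to compound 2, therefore cannot be read in size or direction; the limit of > 100000 nM in this assay, at which 1 of the 2 values shown sits, and the limit of > 50000 nM in this assay, at which 1 of the 2 values shown sits, are all that the two values show. Compound 2 thus stands at a limit, with no number placed on it in this assay.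

Compound 3 `CC(C)c1cccc(C(C)C)c1OC(=O)NS(=O)(=O)Oc1c(F)cccc1F` differs from compound 2 by 2,6-difluorophenyl in place of 2,4-difluorophenyl on an oxygen. Among the compounds with values here, no measured step carries this kind of change, and the only step available is unreadable, so nothing in the data sets a size or a direction for this assay here. The expectation for compound 3 is that it stays where compound 2 stands, so that the step that the limit leaves unreadable from compound 2 to compound 3 is expected to be none beyond the scatter. Compound 3 is estimated at 60000 nM, with a range from 15000 nM to 250000 nM, and it is expected most likely to be reported again only as a limit.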

Compound 3, half-maximal inhibitory concentration: 38000 nM
Compound 3: middle estimate off by 1.6-fold (0.20 log units), on the high side, and the stated range covers the measured number.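

Going by these compounds alone, compound 3 supplies the first true number of the series in this assay, whereas the earlier step could not be read in size or direction, and it shows that an aryl group on this oxygen can give a measurable value. Going from 2,4-difluorophenyl to 2,6-difluorophenyl gives an at least 1.3-fold lower number from compound 2 to compound 3 (0.11 log units; that floor lies within the scatter), so the data do not establish that this change matters, nor do they cap its size, and the value for compound 2 is only a limit: the limit of > 50000 nM in this assay, at which 1 of the 3 values shown sits. The step of an at least 2.6-fold lower number from compound 1 to compound 3 (0.42 log units; beyond the scatter) is the one reading here beyond the scatter, and it is itself a floor, so for this single pair 2,6-difluorophenoxy on the sulfonyl sulfur gives the lower number compared with morpholin-4-yl.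

Going by these compounds, how an unsubstituted phenyl or a 2,6-dichlorophenyl on the same oxygen would compare with compound 3 stays open, and with it whether the fluorines contribute at all. Also open, on these data alone, is whether the oxygen itself counts, which a methylene or an anilino nitrogen in its place on the sulfonyl sulfur would bear on.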